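Triazole-linked furanone series: removing the aryl group on the triazole

This account rests on a few compounds, and the source may have more. Where it says the series, first, only, none or still open, it means among the compounds named here.

Measured so far:
- compound 1, `COc1ccc(-c2cn(C/C=C3\OC(=O)C(OCc4ccccc4)=C3OCc3ccccc3)nn2)cc1`: > 100000 nM
- compound 2, `COc1ccccc1-c1cn(C[C@H](O)[C@H]2OC(=O)C(OCc3ccccc3)=C2OCc2ccccc2)nn1`: 50 nM
- compound 3, `CC(C)(C)OC(=O)N1CCN(C(=S)SCc2cn(C[C@H](O)[C@H]3OC(=O)C(OCc4ccccc4)=C3OCc3ccccc3)nn2)CC1`: 60 nM

In an ADME assay on HFF cells (Homo sapiens) for cytotoxicity, read by MTT assay, with a stated time of 72 h (on this read-out higher numbers stand for weaker inhibition and lower numbers for stronger inhibition), compound 2 gives 50 nM. Compound 3 gives 60 nM, a number within the usual scatter of that of compound 2, so no order between the two is claimed. Compound 1 gives > 100000 nM, which is a limit of this assay and not a number; it sits at the limit of > 100000 nM in this assay, at which 1 of the 3 values shown sits. Within the data shown here, no step between two measured compounds that differ in a single place is available, so nothing here sets the size of any single change.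

Compound 4, `O=C1O[C@H]([C@@H](O)Cn2ccnn2)C(OCc2ccccc2)=C1OCc1ccccc1`, has not been measured. It differs from compound 2 by hydrogen in place of 2-methoxyphenyl on an aromatic carbon. The step is expected to weaken inhibition, so a larger number, a step of a 12-fold higher number from compound 2 to compound 4 (1.08 log units; beyond the scatter) beyond the scatter. Compound 4 is estimated at 600 nM, between 120 nM and 6000 nM.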

Compound 4, half-maximal inhibitory concentration: 610 nM
Beside the measured number, compound 4's estimate is 1.0-fold (0.01 log units) below it; the range from low to high includes it.
By their numbers in this assay, from the lowest: compounds 2 and 3 (each within the scatter of the next); then compound 4. At a limit, above all of these: compound 1.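

In this assay the step of a 12-fold higher number from compound 2 to compound 4 (1.09 log units; beyond the scatter) gives the series its first size for a single change, here hydrogen in place of 2-methoxyphenyl on an aromatic carbon. Compound 4 still gives 610 nM with only hydrogen there, so a measurable number at this position does not need the aryl group. Nothing measured here bears on why the step has this size. Open, as far as these compounds go, is where an amine, a carboxylic acid or a longer chain on this carbon would fall relative to compound 2 and compound 4.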